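Ethyl for chloro on the benzothiophene of compound 3

The compounds below may be only part of what the source reports. "The series", "measured", "known", "first", "only" and "open" are said of these compounds alone.

Measured so far, in an assay on HEK293 cells for displacement of a labelled ligand from Urotensin-2 receptor (Homo sapiens), read by fluorescence, with a stated time of 90 min; a higher number here means a weaker inhibitor, a lower number a stronger inhibitor:
compound 1 `O=C(NC1CCN(Cc2ccc(OC3CCNCC3)c(Br)c2)CC1)c1cccs1`, 130 nM
compound 2 `O=C(NC1CCN(Cc2ccc(OC3CCNCC3)c(Br)c2)CC1)c1cc2cc(F)ccc2s1`, 53 nM
compound 3 `O=C(NC1CCN(Cc2ccc(OC3CCNCC3)c(Br)c2)CC1)c1cc2cc(Cl)ccc2s1`, 51 nM

Compound 3 has the lowest number of the three, though its gap to compound 2 is within the scatter, as shown by a 1.0-fold lower number from compound 2 to compound 3 (0.02 log units; within the scatter); only against compound 1 does it stand clearly apart (a 2.5-fold lower number from compound 1 to compound 3 (0.41 log units; beyond the scatter)). Compound 4 `CCc1ccc2sc(C(=O)NC3CCN(Cc4ccc(OC5CCNCC5)c(Br)c4)CC3)cc2c1` differs from compound 3 by ethyl in place of chloro on an aromatic carbon. Among the compounds with values here, the only measured step at this position is a 1.0-fold lower number from compound 2 to compound 3 (0.02 log units; within the scatter), which was within the scatter; no step with an ethyl group exists. Compound 4 is therefore expected to sit close to compound 3, with a step of about a 1.1-fold higher number from compound 3 to compound 4 (0.03 log units; within the scatter) in this assay. The estimate for compound 4 is 55 nM, with a range from 25 nM to 120 nM.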

Compound 4, half-maximal inhibitory concentration: 180 nM
Compound 4: the middle estimate sits 3.3-fold (0.51 log units) below what was measured; the whole stated range lies below it.
By their numbers in this assay, from the lowest: compounds 3 and 2 (each within the scatter of the next); then compounds 1 and 4 (each within the scatter of the next).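

The step from halogen to ethyl at this position is not neutral, although fluoro and chloro could not be told apart there: in this assay there is a 3.5-fold higher number from compound 3 to compound 4 (0.55 log units; beyond the scatter) and a 3.4-fold higher number from compound 2 to compound 4 (0.53 log units; beyond the scatter). The advantage of the halogenated benzothiophenes over thiophen-2-yl does not carry over to 5-ethyl-1-benzothiophen-2-yl, which shows a 1.4-fold higher number from compound 1 to compound 4 (0.14 log units; within the scatter). Nothing available accounts for this change. On these data alone, whether methyl, which is smaller than ethyl, or a longer chain such as propyl would behave like ethyl remains open. So does the outcome with methoxy or an amine at this position.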